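Trimming propyl to methyl on a shared REV1 scaffold

The source may report more compounds than this note shows. Statements on the series, on what has been measured and on what is new or still open speak of the compounds shown alone.

Measured compounds:
compound 1, `CC(=O)N1CCC(C(=O)Nc2sc3c(c2C(=O)NC2CC2)CCC(C)C3)CC1`, 2500 nM
compound 2, `CCCC1CCc2c(sc(NC(=O)C3CCN(C(C)=O)CC3)c2C(N)=O)C1`, 4900 nM
compound 3, `CCCc1cc(C(=O)OCC)c(NC(=O)C2CCN(C(C)=O)CC2)s1`, 5900 nM

The three compounds were tested in an assay for displacement of a labelled ligand from DNA repair protein REV1 (Homo sapiens), read by fluorescence polarization, with a stated time of 1 h; on this read-out lower numbers stand for stronger inhibition and higher numbers for weaker inhibition. Compound 1 gives 2500 nM, compound 2 gives 4900 nM and compound 3 gives 5900 nM in this assay. Compound 2 stands second highest of the three numbers, with compound 3 nearest and compound 1 furthest; both gaps fall within the usual scatter of repeated measurements, so the three values cannot be told apart with confidence.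

Compound 4, `CC(=O)N1CCC(C(=O)Nc2sc3c(c2C(N)=O)CCC(C)C3)CC1`, has not yet been measured. It differs from compound 2 in one place: hydrogen in place of ethyl on a saturated chain carbon bound to a saturated ring carbon. Among the measured compounds shown here, no pair of measured compounds differing in only that place is available, so the size of this step is unknown. Compounds 1 and 2 both carry a saturated ring on the shared core with either group present, and their values sit within the scatter of each other, which points to a small step. The step from compound 2 to compound 4 is therefore expected to be small, a 1.2-fold lower number from compound 2 to compound 4 (0.09 log units; within the scatter), with no direction beyond the scatter. Compound 4 is estimated at 4000 nM in this assay, within a range from 1500 nM to 12000 nM.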

Compound 4, half-maximal inhibitory concentration: 13200 nM
Beside the measured number, compound 4's estimate is 3.3-fold (0.52 log units) below it; the measured number lies above the stated range.
By their numbers in this assay, from the lowest: compounds 1, 2 and 3 (each within the scatter of the next, the first and the last beyond it); then compound 4.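

In this assay, hydrogen in place of ethyl on a saturated chain carbon bound to a saturated ring carbon gives a 2.7-fold higher number from compound 2 to compound 4 (0.43 log units; beyond the scatter), so trimming propyl to methyl at this position is not a neutral change. Hydrogen in place of cyclopropyl on an amide-type nitrogen gives a 5.3-fold higher number from compound 1 to compound 4 (0.72 log units; beyond the scatter), which shows that the number also responds to the group at this second place on the shared core. Nothing available gives a reason for either step.

As far as these compounds go, whether a longer chain such as butyl would lower the number further than propyl does remains open, as does the effect of an amine or a hydroxyl at the end of that chain. From the compounds shown here alone, it is also open how propyl and cyclopropyl would behave together on the shared core.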